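A ring-free group replaces phenyl in compound 1

The source may report more compounds than this note shows. Statements on the series, on what has been measured and on what is new or still open speak of the compounds shown alone.

In a functional assay on NCI-H460 cells (Homo sapiens) for cytotoxicity, read by MTT assay, with a stated time of 3 days (a higher number here means a weaker inhibitor, a lower number a stronger inhibitor), compound 1 `N#Cc1c(Nc2ccccc2)nc(SCc2nc3ccccc3[nH]2)nc1-c1ccccc1` gives 4.54 nM and compound 2 `N#Cc1c(Nc2ccccn2)nc(SCc2nc3ccccc3[nH]2)nc1-c1ccccc1` gives 2.8 nM while compound 3 `N#Cc1c(Nc2nccs2)nc(SCc2nc3ccccc3[nH]2)nc1-c1ccccc1` gives 3.37 nM so compound 1 lies within the scatter of both. Compound 4 `N#Cc1c(NNC(N)=S)nc(SCc2nc3ccccc3[nH]2)nc1-c1ccccc1` differs from compound 1 on a nitrogen on an aromatic ring (a group of 4 heavy atoms (1 carbon, 2 nitrogen, 1 sulfur; no ring) in place of a group of 6 heavy atoms (6 carbon; one six-membered aromatic ring of carbon only), on a nitrogen on an aromatic ring). Two measured swaps at that place bear on this, with a 1.6-fold lower number from compound 1 to compound 2 (0.21 log units; within the scatter) for pyridin-2-yl and a 1.3-fold lower number from compound 1 to compound 3 (0.13 log units; within the scatter) for 1,3-thiazol-2-yl, and both stayed within the scatter. Each of those swaps kept a ring, however, and the new group has none, so they guide only loosely. With no direction to go on, the expected change is small (a 1.1-fold higher number from compound 1 to compound 4 (0.04 log units; within the scatter)), so no step beyond the scatter is expected in this assay here. Compound 4 is expected at 5 nM (estimated range 1.5 nM to 20 nM).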

Compound 4, half-maximal inhibitory concentration: 3.37 nM
Beside the measured number, compound 4's estimate is 1.5-fold (0.17 log units) above it, and the stated range covers the measured number.
By their numbers in this assay, from the lowest: compounds 2, 3, 4 and 1 (each within the scatter of the next).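

In this assay, the steps of a 1.3-fold lower number from compound 1 to compound 4 (0.13 log units; within the scatter) and no change at the digits printed from compound 3 to compound 4 (within the scatter) and a 1.2-fold higher number from compound 2 to compound 4 (0.08 log units; within the scatter) all lie within the scatter. On this nitrogen, then, a group with no ring gives a number matching those of the three ring-bearing groups, so a ring at this place is not required for these low numbers. Nothing here explains why the numbers stay so close.

Still open, from the compounds shown here alone, is whether a much smaller group, such as a plain amine, or a larger one, such as a longer alkyl chain or a carboxylic acid, would stay within the scatter too.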